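Propylamino in place of piperidin-1-yl on the shared core

The source may report more compounds than this note shows. Statements on the series, on what has been measured and on what is new or still open speak of the compounds shown alone.

Compound 1 `c1nc(N2CCC2)c2ncn(CC3CC3)c2n1` and compound 2 `c1nc(N2CCCCC2)c2ncn(CC3CC3)c2n1` share a core and differ at one aromatic carbon. In a functional assay on the whole organism for inhibition, with Rattus norvegicus as the target, at a dose of 25 mg/kg by the intraperitoneal route (a lower number here means less inhibition, a higher number more inhibition at the dose given (going by the name of the read-out)), compound 1 gives 30% and compound 2 gives 28%; the step of a number 2 percentage points lower from compound 1 to compound 2 (within the scatter) is within the scatter, so compound 2 stands level with compound 1. Compound 3 `CCCNc1ncnc2c1ncn2CC1CC1` is not yet measured; it differs from compound 2 by propylamino in place of piperidin-1-yl on an aromatic carbon. Within the data shown here, only the step from compound 1 to compound 2 bears on this, and it was small, so no step beyond the scatter is expected. Compound 3 is estimated at 29%, between 14% and 44%. The step of a number 1 percentage points higher from compound 2 to compound 3 (within the scatter) is expected to stay within the scatter.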

Compound 3, a percentage reported as inhibition, in the whole organism at one dose (the size of the read-out at that dose, not a potency): 0%
Beside the measured number, compound 3's estimate is 29 percentage points above it, and the stated range ends above it.
By their numbers in this assay, from the lowest: compound 3; then compounds 2 and 1 (each within the scatter of the next).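

In this assay, among these compounds, the earlier compounds showed no separation between azetidin-1-yl and piperidin-1-yl on this aromatic carbon, but an open chain here does make a difference. Propylamino in place of piperidin-1-yl gives a number 28 percentage points lower from compound 2 to compound 3 (beyond the scatter), and propylamino in place of azetidin-1-yl gives a number 30 percentage points lower from compound 1 to compound 3 (beyond the scatter). No measurement at hand gives a reason for these steps.

The compounds shown leave open whether the loss goes with the open chain or with the hydrogen on the amine nitrogen, as propylamino differs from both rings in each. Diethylamino, an open-chain amine without that hydrogen, would separate the two.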